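Stereochemical inversion in a sugar sulfonamide series: clearance notes

The source may hold more compounds than are shown below. What is called first, only, known or untested is meant among the compounds shown, and "the series" means these compounds.

Measured compounds:
compound 1 `CCCO[C@@H]1O[C@H](CNC(=O)c2ccc(S(N)(=O)=O)cc2)[C@@H](O)[C@H](O)[C@H]1N` — 1.42 mL/min/kg
compound 2 `CCCO[C@@H]1O[C@H](CNC(=O)c2ccc(S(N)(=O)=O)cc2)[C@@H](O)[C@H](O)[C@@H]1O` — 1.42 mL/min/kg

In an ADME assay on microsomes from liver (Mus musculus) for metabolic stability (on this read-out higher numbers stand for fast clearance and lower numbers for slow clearance), compound 1 gives 1.42 mL/min/kg. In this assay compound 2 gives 1.42 mL/min/kg, level with compound 1 at the digits shown, which is no change within the scatter. Among the measured compounds shown here, no step between measured compounds that differ in one place exists in this set.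

Compound 3 `CCCO[C@@H]1O[C@H](CNC(=O)c2ccc(S(N)(=O)=O)cc2)[C@H](O)[C@H](O)[C@H]1O` has not yet been measured. Against compound 2 the change is the two compounds have the same atoms and bonds and differ only in configuration as drawn: 2 of 5 stereo elements differ; a stereocentre at a saturated ring carbon is drawn S in compound 2 and R in compound 3; a stereocentre at a saturated ring carbon is drawn S in compound 2 and R in compound 3. For the measured compounds named here, with no measured step to draw on, the step of no change at the digits printed from compound 2 to compound 3 (within the scatter) is expected to be none beyond the scatter. Compound 3 is therefore estimated at 1.42 mL/min/kg, with a range from 0.7 mL/min/kg to 2.9 mL/min/kg.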

Compound 3, clearance: 1.38 mL/min/kg
Compound 3: the middle estimate sits 1.0-fold (0.01 log units) above what was measured, within the range that was stated.
By their numbers in this assay, from the lowest: compounds 3, 1 and 2 (each within the scatter of the next).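

In this assay, the change in configuration at two saturated ring carbons comes with a 1.0-fold lower number from compound 2 to compound 3 (0.01 log units; within the scatter). Among the compounds shown here, this is the only readable step in the set, so for this pair the configuration at these two carbons has no effect on clearance beyond the scatter. The comparison isolates configuration from any change of group: the fact that compounds 2 and 3 differ only in the configuration as drawn

The compounds shown leave open whether either stereocentre alone would give the same reading. Also open, going by these compounds, is whether this holds with a carboxylic acid in place of the sulfonamide or a longer chain on the ring oxygen substituent.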